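The source may report more compounds than this note shows. Statements on the series, on what has been measured and on what is new or still open speak of the compounds shown alone.

In an in vitro assay on BTI-TN-5B1-4 cells for inhibition of Amine oxidase [flavin-containing] A (Homo sapiens), read by Amplex Red, with a stated time of 15 min, tested at 100 uM (a lower number here means less inhibition, a higher number more inhibition at the concentration tested (going by the name of the read-out)), compound 1 `N#Cc1ccc(-c2csc(N/N=C\c3cccc4ccccc34)n2)cc1` gives 40%. Compound 2 `C/C(=N/Nc1nc(-c2ccc([N+](=O)[O-])cc2)cs1)c1cccnc1` shares the core and in this assay is reported as "not active" (no number reported), so no single number marks where compound 2 stands; only that verdict, as reported, is known for it.

Compound 3 `C/C(=N/Nc1nc(-c2ccc(F)cc2)cs1)c1cccnc1` differs from compound 2 in one place: fluoro in place of nitro on an aromatic carbon. No measured pair in the series shows this change, so the size of the step in this assay is unknown; a small rise is plausible, but nothing shown requires a move beyond the usual scatter.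

For compound 3 in this assay the expected value is 15%, with a range from 0% to 40%.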

Compound 3, a percentage reported as inhibition, at one concentration (the size of the read-out at that concentration, not a potency): 40%
For compound 3 the middle estimate is 25 percentage points below the measured one; measured number inside the range.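

Within the data shown here, no step from compound 2 to compound 3 can be read in this assay: compound 2 carries a verdict, not a number. The compounds shown leave open how large the step from nitro to fluoro is. No evidence on hand bears on this result.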